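Benzyl substituent change from compound 3 to compound 4

A few compounds are considered here, and "the series" means these few. Any claim that something is new, unique, unknown or untested is made for them only; others in the source may bear on it.

In an ADME assay on cells (Peritoneal macrophage, Mus musculus, strain Balb/c) for cytotoxicity, read by resazurin assay, with a stated time of 72 h (on this read-out higher numbers stand for lower toxicity in this test and lower numbers for higher toxicity in this test), compound 1 (`CC1(Cc2ccccc2)CC(S(=O)(=O)c2ccc(F)cc2)=C(c2ccc(/C(N)=N/O)cc2)O1`) gives 102000 nM, compound 2 (`CC1(Cc2cccc(/C(N)=N/O)c2)CC(S(=O)(=O)c2ccc(F)cc2)=C(c2ccc(/C(N)=N/O)cc2)O1`) gives 50200 nM and compound 3 (`CC1(Cc2ccc([N+](=O)[O-])cc2)CC(S(=O)(=O)c2ccc(F)cc2)=C(c2ccc(/C(N)=N/O)cc2)O1`) gives 97400 nM. Compound 3 stands within the scatter of both others: a 1.0-fold lower number from compound 1 to compound 3 (0.02 log units; within the scatter), and a 1.9-fold higher number from compound 2 to compound 3 (0.29 log units; within the scatter).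

Compound 4 (`Cc1ccccc1CC1(C)CC(S(=O)(=O)c2ccc(F)cc2)=C(c2ccc(/C(N)=N/O)cc2)O1`) differs from compound 3 by 2-methylphenyl in place of 4-nitrophenyl on a saturated chain carbon bound to a saturated ring carbon.

Among the compounds with values here, two measured steps bear on this change. Removing the nitro group gave no step beyond the scatter, a 1.0-fold lower number from compound 1 to compound 3 (0.02 log units; within the scatter), and only the modest 2.0-fold lower number from compound 1 to compound 2 (0.31 log units; beyond the scatter) went beyond it. Within the data shown here, no methyl-bearing analogue has been measured. In this assay the expected step is a 1.0-fold lower number from compound 3 to compound 4 (0.01 log units; within the scatter), none beyond the scatter.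

Compound 4 is estimated at 95000 nM, with an expected range of 55000 nM to 160000 nM.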

Compound 4, half-maximal cytotoxic concentration: 77600 nM
For compound 4 the middle estimate is 1.2-fold (0.09 log units) above the measured one, and the stated range covers the measured number.
By their numbers in this assay, from the lowest: compounds 2, 4, 3 and 1 (each within the scatter of the next, the first and the last beyond it).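

In this assay the 2-methylphenyl group on this saturated chain carbon stays within the scatter of each earlier compound (a 1.3-fold lower number from compound 1 to compound 4 (0.12 log units; within the scatter); a 1.3-fold lower number from compound 3 to compound 4 (0.10 log units; within the scatter); a 1.5-fold higher number from compound 2 to compound 4 (0.19 log units; within the scatter)). Methyl on an aromatic carbon thus joins nitro as a change on this ring that stays within the scatter of the unsubstituted compound 1. Nothing available explains these steps.

Going by these compounds, an amine or a carboxylic acid on this ring remains open, as does a longer chain in place of the benzyl group.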